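Removing the chloromethyl: from compound 2 toward compound 4

The compounds below may be only part of what the source reports. "The series", "measured", "known", "first", "only" and "open" are said of these compounds alone.

Measured compounds:
Compound 1, `CCCc1ccccc1OS(=O)(=O)c1ccc(NC(=O)NCCCCl)cc1`, 15000 nM in a functional assay on MCF7 cells (Homo sapiens) for cytotoxicity, read by sulforhodamine B assay, with a stated time of 48 h; a lower number here means a stronger inhibitor, a higher number a weaker inhibitor.
Compound 2, `Cc1ccccc1NS(=O)(=O)c1cccc(NC(=O)NCCCCl)c1`, 52000 nM in this assay.
Compound 3, `CCCc1ccccc1OS(=O)(=O)c1ccc(NC(=O)NCC)cc1`, 1300 nM in this assay.

Compound 2 gives the highest of the three numbers; compound 1 is nearest to it and compound 3 furthest from it. Compound 1 and compound 3 share one core and differ in a single place: hydrogen in place of chloromethyl on a saturated chain carbon, two bonds along the chain from an amide-type nitrogen. This step gave a 12-fold lower number from compound 1 to compound 3 (1.06 log units; beyond the scatter), a large change in this assay.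

Compound 4, `CCNC(=O)Nc1cccc(S(=O)(=O)Nc2ccccc2C)c1`, is unmeasured. It stands to compound 2 as compound 3 stands to compound 1: hydrogen in place of chloromethyl on a saturated chain carbon, two bonds along the chain from an amide-type nitrogen. The change is the same, made on the same kind of carbon at the same distance from the amide-type nitrogen. The cores of compound 1 and compound 2 differ, and that difference is not broken down here.

Within the data shown here, from compound 2 to compound 4 the step is expected to be a 10-fold lower number from compound 2 to compound 4 (1.02 log units; beyond the scatter), resting on the one prior example, a 12-fold lower number from compound 1 to compound 3 (1.06 log units; beyond the scatter), with a wider range because the cores are not identical. Compound 4 is estimated at 5000 nM, between 1500 nM and 20000 nM.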

Compound 4, half-maximal inhibitory concentration: 108000 nM
For compound 4 the middle estimate is 22-fold (1.33 log units) below the measured one; the measured number lies above the stated range.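

In this assay, hydrogen in place of chloromethyl gave a 2.1-fold higher number from compound 2 to compound 4 (0.32 log units; beyond the scatter), so the change did not carry over from the core of compound 1 to the core of compound 2 in either direction or size: the same change on two cores in this assay, a 12-fold lower number (1.06 log units; beyond the scatter) from compound 1 to compound 3 and a 2.1-fold higher number (0.32 log units; beyond the scatter) from compound 2 to compound 4, 24-fold (1.38 log units) apart, beyond the scatter of two such steps

This shows that, for these two pairs, the outcome of removing the chloromethyl depends on the core that carries it, and that the step seen on one core cannot be taken as a guide to the other. It does not show which part of the cores is responsible, as compound 1 and compound 2 differ in more than one place, and two pairs set no rule for the wider series.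

The compounds shown leave open how a longer chain, a hydroxymethyl or an aminomethyl in place of the chloromethyl would behave on either core. They also leave open what a core carrying only part of the difference between compound 1 and compound 2 would give.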